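The compounds below may be only part of what the source reports. "The series", "measured", "known", "first", "only" and "open" are said of these compounds alone.

Compound 2 `CN1CCN(CCNCc2cn(-c3ccc(F)cc3F)nc2-c2cccc(N(C)C)c2)CC1` stands at the edge of what an ADME assay on Huh-7 cells (Homo sapiens) for cytotoxicity (a higher number here means that more compound is tolerated, a lower number that less compound is tolerated), can report: its value, > 20000 nM, is a limit and not a number. Compound 1 `CN1CCN(CCNCc2cn(-c3ccc(F)cc3F)nc2-c2ccc(C(F)(F)F)cc2)CC1` gives 20000 nM in this assay. Compound 3 `Cc1ccccc1-c1nn(-c2ccc([N+](=O)[O-])cc2)cc1CNCCN1CCN(C)CC1` is likewise reported in this assay only as a limit, > 20000 nM. Among the compounds with values here, the one measured step, a number no lower from compound 1 to compound 2 (the limit leaves the size open), ends at that limit, so its size cannot be read. What remains firm is the limit of > 20000 nM in this assay, at which 2 of the 3 values shown sit, where most of the measured values gather. The change now followed is methyl in place of dimethylamino on an aromatic carbon, which gives compound 4 `Cc1cccc(-c2nn(-c3ccc(F)cc3F)cc2CNCCN2CCN(C)CC2)c1`. Within the data shown here, no measured step covers this particular change, and the single step that is known has no readable size, so nothing points to a shift beyond the scatter in either direction. The step this estimate means, a number no higher from compound 2 to compound 4 (the limit leaves the size open), is expected to stay within the scatter, with a fair chance that this assay again returns only a limit. Compound 4 is estimated at 20000 nM, with a range from 10000 nM to 40000 nM.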

Compound 4, half-maximal cytotoxic concentration: > 20000 nM
Compound 4 ended at the assay's limit; the forecaster's own chance of this, stated with the estimate: 70%; the middle value sits exactly at the limit.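

In this assay, compound 4 is again reported only as a limit, > 20000 nM, and not as a number. The new step that starts from a plain number, a number no lower from compound 1 to compound 4 (the limit leaves the size open), ends at that limit. This shows that a small methyl in place of dimethylamino on this aromatic carbon still gives a result at the edge of what the assay reports, though neither new step can be read for size. The values shown now gather more tightly at that edge: the limit of > 20000 nM in this assay, at which 3 of the 4 values shown sit.

The compounds shown leave open whether another group on this aromatic carbon, such as a carboxylic acid or a longer chain, would give a readable value instead of a limit. Within the data shown here, they also leave open how far compound 2 and compound 4 truly lie from compound 1, the only one with a plain number, 20000 nM.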